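Pyrazolyl Extension of the Aryl Tail: Tolerability Expectation

The source may hold more compounds than are shown below. What is called first, only, known or untested is meant among the compounds shown, and "the series" means these compounds.

Compound 3 `Cc1ccc([C@@H](C)Nc2nc(C)c(-c3nc4cnccc4s3)c(N[C@@H]3C[C@H](CO)[C@@H](O)[C@H]3O)n2)cc1` gives 25000 nM in an ADME assay on cells (Homo sapiens) for cytotoxicity, read by polymerase chain reaction, with a stated time of 3 days (a higher number here means that more compound is tolerated, a lower number that less compound is tolerated), level with compound 2 `Cc1nc(N[C@@H](C)c2ccccc2)nc(N[C@@H]2C[C@H](CO)[C@@H](O)[C@H]2O)c1-c1nc2cnccc2s1` at 25000 nM and together the highest of three numbers; compound 1 `CNc1nc(C)c(-c2nc3cnccc3s2)c(N[C@@H]2C[C@H](CO)[C@@H](O)[C@H]2O)n1` sits at 14000 nM, the step being a 1.8-fold higher number from compound 1 to compound 3 (0.25 log units; within the scatter). Compound 4 `Cc1nc(N[C@H](C)c2ccc(-c3cnn(C)c3)cc2)nc(N[C@@H]2C[C@H](CO)[C@@H](O)[C@H]2O)c1-c1nc2cnccc2s1` carries the change (1-methyl-1H-pyrazol-4-yl in place of methyl on an aromatic carbon). Among the compounds with values here, the closest precedent is no change at the digits printed from compound 2 to compound 3 (within the scatter), and the earlier step of a 1.8-fold higher number from compound 1 to compound 2 (0.25 log units; within the scatter) was also within the scatter, so the whole series has moved only marginally. Compound 4 is therefore expected to show no step beyond the scatter, estimated as no change at the digits printed from compound 3 to compound 4 (within the scatter). Compound 4 is estimated at 25000 nM, within a range from 12000 nM to 50000 nM.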

Compound 4, half-maximal cytotoxic concentration: 25000 nM
Estimate against measurement, compound 4: no gap at the digits printed; low and high end bracket the measured number.
By their numbers in this assay, from the lowest: compounds 1, 2, 3 and 4 (each within the scatter of the next).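

The step of no change at the digits printed from compound 3 to compound 4 (within the scatter) in this assay shows that this position, on an aromatic carbon para to a large group, accepts more than hydrogen or methyl. Here 1-methyl-1H-pyrazol-4-yl brings 6 heavy atoms, a five-membered aromatic ring and 2 hydrogen-bond acceptors, and the number still stays within the scatter. Nothing measured here gives a reason for this result. As far as these compounds go, whether a carboxylic acid or a primary amine at the same carbon would also leave the number in place stays open.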